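Replacing 2,4-dichlorophenyl with cyclohexyl in compound 4

The source may hold more compounds than are shown below. What is called first, only, known or untested is meant among the compounds shown, and "the series" means these compounds.

In a functional assay on HepG2 cells (Homo sapiens) for antiproliferative activity, read by MTT assay, with a stated time of 48 h (a higher number here means a weaker inhibitor, a lower number a stronger inhibitor), compound 1 `CN(C)c1ccc(NC(=O)Nc2cccc(CNc3nccnc3Cl)c2)cc1` gives > 40000 nM, which is a limit of the assay and not a number. Compound 2 `Cc1ccc(NC(=O)Nc2cccc(CNc3nccnc3Cl)c2)c(C)c1` gives 9290 nM and compound 3 `O=C(Nc1cccc(CNc2nccnc2Cl)c1)Nc1ccc(Cl)cc1Cl` gives 7230 nM. The gap between these two, a 1.3-fold lower number from compound 2 to compound 3 (0.11 log units; within the scatter), lies within the scatter, so compound 3 stands level with compound 2. Compound 4 `O=C(Nc1cccc(CNc2nccnc2Cl)c1)NC1CCCCC1` differs from compound 3 at one place: cyclohexyl in place of 2,4-dichlorophenyl on an amide-type nitrogen. Among the compounds with values here, earlier swaps at this nitrogen gave an at least 5.5-fold lower number from compound 1 to compound 3 (0.74 log units; beyond the scatter) and an at least 4.3-fold lower number from compound 1 to compound 2 (0.63 log units; beyond the scatter), so changes here can exceed the scatter, yet no measured compound carries a non-aromatic ring at this place. A modest step toward weaker inhibition is therefore expected in this assay, a 2.5-fold higher number from compound 3 to compound 4 (0.40 log units; beyond the scatter). For compound 4 the estimated value is 18000 nM, with an expected range of 6000 nM to 50000 nM.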

Compound 4, half-maximal inhibitory concentration: > 40000 nM
Compound 4 gave a limit, no number; the forecaster's own chance of this, stated with the estimate: 35%; middle value at least 2.2-fold (0.34 log units) away from the limit.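

In this assay, cyclohexyl on this amide-type nitrogen gives an at least 5.5-fold higher number from compound 3 to compound 4 (0.74 log units; beyond the scatter), and it gives an at least 4.3-fold higher number from compound 2 to compound 4 (0.63 log units; beyond the scatter). A six-membered carbon ring therefore does not suffice here: among the compounds shown, only the substituted aromatic rings of compound 2 and compound 3 give measurable numbers. Compound 1 also carries an aromatic ring, and it goes against any simple aromatic rule. Going by these compounds, the step between compound 1 and compound 4 cannot be read because both values are limits: the limit of > 40000 nM in this assay, at which 2 of the 4 values shown sit. Still open is whether plain phenyl or a piperidine ring at this nitrogen would give a measurable number.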